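Adding a Methoxy to Compound 1

A few compounds are considered here, and "the series" means these few. Any claim that something is new, unique, unknown or untested is made for them only; others in the source may bear on it.

Measured so far:
compound 1, `COc1ccc2nc(C)cc(OCC(=O)Nc3cc(C)cc(C)c3)c2c1`, 20000 nM
compound 2, `Cc1cc(C)cc(NC(=O)COc2cc(C)nc3ccccc23)c1`, a limit of the assay, > 100000 nM
compound 3, `COc1ccc2nc(C)cc(OC(C)C(=O)Nc3cc(C)cc(C)c3)c2c1`, 39800 nM

In a toxicity assay on HepG2 cells (Homo sapiens) for inhibition, read by CellTiter-Glo, with a stated time of 48 h (a lower number here means a stronger inhibitor, a higher number a weaker inhibitor), compound 1 gives the lowest of the two numbers, and compound 3 sits within the scatter of it (a 2.0-fold higher number from compound 1 to compound 3 (0.30 log units; within the scatter)). The value of compound 2 is only a limit (the limit of > 100000 nM in this assay, at which 1 of the 3 values shown sits). Compound 4, `COc1ccc2nc(C)cc(OCC(=O)Nc3cc(C)c(OC)c(C)c3)c2c1`, differs from compound 1 by methoxy in place of hydrogen on an aromatic carbon. For the measured compounds named here, two measured steps bear on this: removing a methoxy from the shared core gave an at least 5.0-fold higher number from compound 1 to compound 2 (0.69 log units; beyond the scatter), while adding a methyl on the chain gave a 2.0-fold higher number from compound 1 to compound 3 (0.30 log units; within the scatter). A methoxy entering at a new place on a different ring is expected to move the number little, so compound 4 is estimated at 15000 nM (range 5000 nM to 50000 nM), a step of a 1.3-fold lower number from compound 1 to compound 4 (0.12 log units; within the scatter) expected to stay within the scatter.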

Compound 4, half-maximal inhibitory concentration: 7940 nM
The estimate for compound 4 lay 1.9-fold (0.28 log units) above the measured number; the range from low to high includes it.
By their numbers in this assay, from the lowest: compound 4; then compounds 1 and 3 (each within the scatter of the next). At a limit, above all of these: compound 2.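

In this assay, for the compounds shown here, the methoxy on the six-membered aromatic ring of carbon only, ortho to two methyl groups and para to a large group, gives a 2.5-fold lower number from compound 1 to compound 4 (0.40 log units; beyond the scatter) and is the first single change here to lower the number beyond the scatter. The earlier steps shown here touched the shared core and the chain, so this one shows that the other ring also affects the number.

From the compounds shown here alone, whether an amine or a longer chain such as ethoxy at this place would move the number in the same direction stays open. Nothing among the data shown explains the step.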